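Chloro for Fluoro on a Fused Core: Cytotoxicity Outlook

The source may hold more compounds than are shown below. What is called first, only, known or untested is meant among the compounds shown, and "the series" means these compounds.

Of the compounds shown here, three have been measured in an ADME assay on RAW264.7 cells (Mus musculus) for cytotoxicity, read by MTT assay, with a stated time of 24 h; a higher number here means that more compound is tolerated, a lower number that less compound is tolerated. Compound 1 `O=C(Nc1ccc(Cl)cc1F)c1cc(Cl)ccc1O` gives 8000 nM, and compound 3 `O=C(Nc1ccc(Cl)cc1F)c1cc(F)ccc1O` gives 7700 nM in this assay. Compound 2 `O=c1oc2ccc(F)cc2c(=O)n1-c1ccc(I)cc1F`, built on a different core, gives 6000 nM in this assay; the difference between the two cores is not broken down here.

Compound 4 `O=c1oc2ccc(Cl)cc2c(=O)n1-c1ccc(I)cc1F` has not yet been measured. It differs from compound 2 by chloro in place of fluoro on an aromatic carbon. The same kind of change links compound 3 to compound 1, where (chloro in place of fluoro on an aromatic carbon); in compound 1 the changed carbon is meta to a large group and para to a hydroxy group, whereas in compound 4 it sits on a ring that is part of a fused system, meta and para to a fused ring. That earlier step gave a 1.0-fold higher number from compound 3 to compound 1 (0.02 log units; within the scatter).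

Because a 1.0-fold higher number from compound 3 to compound 1 (0.02 log units; within the scatter) was within the scatter, the step from compound 2 to compound 4 is expected to be about no change at the digits printed from compound 2 to compound 4 (within the scatter) in this assay. Compound 4 is therefore estimated at 6000 nM in this assay, likely between 3000 nM and 12000 nM.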

Compound 4, half-maximal cytotoxic concentration: 6900 nM
The estimate for compound 4 lay 1.2-fold (0.06 log units) below the measured number; low and high end bracket the measured number.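

In this assay, chloro in place of fluoro on the aromatic carbon of the fused core gave a 1.2-fold higher number from compound 2 to compound 4 (0.06 log units; within the scatter), a step that does not stand clear of the usual scatter. Set beside the earlier step on the other core, the same change reads alike on both: the same change on two cores in this assay, a 1.0-fold higher number (0.02 log units; within the scatter) from compound 3 to compound 1 and a 1.2-fold higher number (0.06 log units; within the scatter) from compound 2 to compound 4, 1.1-fold (0.04 log units) apart, within the scatter of two such steps. This shows that, for these two pairs, the change carried from one core to the other without a step that can be told from the scatter; it does not show that the same would hold on a further core, at another ring position or in a different assay, and two steps this small cannot reveal a subtle dependence on the core.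

The compounds shown leave open whether a group of another kind on that aromatic carbon, such as an amine, a methoxy group or a carboxylic acid, would give a step beyond the scatter. Also open, from the compounds shown here alone, is whether bromo would behave as chloro and fluoro do here.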